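Hydroxamic acids on a shared core: a benzamido cap

The source may report more compounds than this note shows. Statements on the series, on what has been measured and on what is new or still open speak of the compounds shown alone.

Measured so far:
compound 1 `Cc1cccc(CN2CCC=C(CCC(=O)NO)C2=O)c1` – > 10000 nM
compound 2 `O=C(CCC1=CCCN(Cc2ccc(F)cc2)C1=O)NO` – "not determined" (no result reported)
compound 3 `O=C(CCC1=CCCN(CCCc2ccc3ccccc3c2)C1=O)NO` – 300 nM

Three compounds share the same core, each carrying a hydroxamic acid chain, and differ only in the group attached to the ring nitrogen. In a functional assay on PC-3 cells (Homo sapiens) for inhibition, read by sulforhodamine B assay (on this read-out lower numbers stand for stronger inhibition of growth and higher numbers for weaker inhibition of growth), compound 1 gives > 10000 nM, which is a limit of the assay and not a number (the limit of > 10000 nM in this assay, at which 1 of the 3 values shown sits). In this assay compound 3 gives 300 nM. For compound 2 this assay reports "not determined" (no result reported), so it stands nowhere on the scale, with no number of its own.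

Compound 4 `O=C(CCC1=CCCN(Cc2ccc(NC(=O)c3ccccc3)cc2)C1=O)NO` is yet to be tested. It differs from compound 2 in one place: benzamido in place of fluoro on an aromatic carbon. Among the measured compounds shown here, with no number for compound 2, no step can be drawn, and the only guide is that a larger cap, as in compound 3, gave a measurable value where the smaller cap of compound 1 gave only a limit. A value between these two is expected, leaning toward measurable growth inhibition. Compound 4 is estimated at 1500 nM, with a likely range from 250 nM to 8000 nM.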

Compound 4, concentration for 50% growth inhibition: > 10000 nM
Compound 4 ended at the assay's limit (the forecaster's own chance of this, stated with the estimate: 25%); middle value at least 6.6-fold (0.82 log units) away from the limit.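

No step can be read between compound 2 and compound 4: compound 2 has no result in this assay to compare against. Compound 4 gives > 10000 nM as a limit of the assay and not a number. The compounds shown leave open how benzamido compares with fluoro in this position.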